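This account rests on a few compounds, and the source may have more. Where it says the series, first, only, none or still open, it means among the compounds named here.

Of the compounds shown here, two on a shared core have been measured in an in vitro assay on Sf21 cells for inhibition of high affinity 3',5'-cyclic-AMP phosphodiesterase 7A (Homo sapiens); on this read-out higher numbers stand for weaker inhibition and lower numbers for stronger inhibition. Compound 1 `CNc1nc(NC)nc(NC2(C#N)CCCCC2)n1` carries a methylamino group at the place in question. In this assay compound 1 reaches only a limit, > 1000 nM. Going by the values given here, compound 2 `CNc1nc(NC2(C#N)CCCCC2)nc(SC)n1` carries a methylsulfanyl group there instead, and in this assay compound 2 gives 46 nM, the only number so far. Among the compounds with values here, the step of an at least 21-fold lower number from compound 1 to compound 2 (1.33 log units; beyond the scatter) is the single measured step, and it rests on the limit (the limit of > 1000 nM in this assay, at which 1 of the 2 values shown sits), so its size is known only as a lower bound. Compound 3 `CNc1nc(NC2(C#N)CCCCC2)nc(-n2cnc(C#N)n2)n1` is the next compound: 3-cyano-1H-1,2,4-triazol-1-yl in place of methylsulfanyl on an aromatic carbon. Within the data shown here, no measured step covers this change; the one step known concerns a different exchange at the same place, and it shows only that this place can move the number by a large amount. A step of modest size toward weaker inhibition is therefore expected, a 3.3-fold higher number from compound 2 to compound 3 (0.51 log units; beyond the scatter), with wide uncertainty. For compound 3 the expected value is 150 nM, within 20 nM to 1500 nM.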

Compound 3, half-maximal inhibitory concentration: > 5000 nM
Compound 3 was reported as a limit; the forecaster's own chance of this, stated with the estimate: 20%; middle value at least 33-fold (1.52 log units) away from the limit.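

At this place on the shared core, the change from methylsulfanyl to 3-cyano-1H-1,2,4-triazol-1-yl in this assay gives an at least 100-fold higher number from compound 2 to compound 3 (2.03 log units; beyond the scatter). Read with an at least 21-fold lower number from compound 1 to compound 2 (1.33 log units; beyond the scatter), this means that both exchanges shown at this place, to methylamino and to the triazolyl group, go with weaker inhibition than methylsulfanyl, and the second result extends this from a small open group to one carrying a five-membered aromatic ring. Compound 3 is reported only as a limit, and the size of its step is known only as a lower bound, while the step between compound 1 and compound 3 cannot be read, because each of these two compounds stands at a limit: the limit of > 5000 nM in this assay, at which 1 of the 3 values shown sits.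

The compounds shown leave open which of the two groups at a limit is the poorer one, and whether the number follows the sulfur atom or the methyl group of methylsulfanyl, a question that ethylsulfanyl or methoxy at this place would address. They also leave open how much of the result belongs to the nitrile, which a plain 1H-1,2,4-triazol-1-yl group would separate from the ring.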